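A few compounds are considered here, and "the series" means these few. Any claim that something is new, unique, unknown or untested is made for them only; others in the source may bear on it.

Measured so far:
compound 1, `COc1cccc(-c2c(S(=O)(=O)c3ccc(C)c(F)c3)cnc3c(F)cccc23)c1`: 4.02 mL/min
compound 2, `COc1ccc(-c2c(S(=O)(=O)c3cc(Cl)cc(Cl)c3)cnc3c(F)cccc23)cc1`: 2.11 mL/min

In an ADME assay on microsomes from liver (Homo sapiens) for metabolic stability, tested at 2.5 uM (a lower number here means slower removal, a higher number faster removal of the compound), compound 2 gives 2.11 mL/min, and in the same assay compound 1 gives 4.02 mL/min. Compound 2 stands at the low end of the two numbers shown, but its gap to compound 1 lies within the usual scatter, so the two are not distinguished by these data. Within the data shown here, compound 1 and compound 2 differ from each other in more than one place, so no single-point step between measured compounds is available.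

Compound 3, `COc1cccc(-c2c(S(=O)(=O)c3cc(Cl)cc(Cl)c3)cnc3c(F)cccc23)c1`, is to be measured in this assay. It differs from compound 2 in one place: 3-methoxyphenyl in place of 4-methoxyphenyl on an aromatic carbon. Among the measured compounds shown here, compound 1, which carries the same 3-methoxyphenyl as compound 3, sits within the scatter of compound 2 on the value it gives, so nothing among the measured compounds indicates that this exchange shifts the number appreciably. The step in this assay is therefore expected to stay within the scatter, in no clear direction, a 1.3-fold higher number from compound 2 to compound 3 (0.12 log units; within the scatter). Compound 3 is expected to give about 2.8 mL/min, with a range from 1.4 mL/min to 5.6 mL/min.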

Compound 3, intrinsic clearance in a liver preparation (reported as CLH), per the amount of preparation that the assay uses: 2.31 mL/min
Estimate against measurement, compound 3: 1.2-fold (0.08 log units) above; low and high end bracket the measured number.
By their numbers in this assay, from the lowest: compounds 2, 3 and 1 (each within the scatter of the next).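

In this assay, 3-methoxyphenyl in place of 4-methoxyphenyl on the aromatic carbon opposite the ring nitrogen, with 3,5-dichlorophenyl on the sulfonyl sulfur in both compounds, gives a 1.1-fold higher number from compound 2 to compound 3 (0.04 log units; within the scatter). This single-place comparison therefore does not distinguish the two methoxyphenyl groups at this position. With 3-methoxyphenyl common to both compounds, 3,5-dichlorophenyl in place of 3-fluoro-4-methylphenyl on the sulfonyl sulfur gives a 1.7-fold lower number from compound 1 to compound 3 (0.24 log units; within the scatter), so this exchange is not distinguished from repeat measurement either.

Still open, as far as these compounds go, is whether a group of another kind on this aromatic carbon, such as an amine or a carboxylic acid in place of the methoxy group, would give a number beyond the scatter. Also open, from the compounds shown here alone, is whether a nitrile or an amide on the aryl group at the sulfonyl sulfur would do so, since the two aryl groups compared here carry only halogen or methyl substituents.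

No measurement at hand bears on why these compounds give numbers within the scatter of one another.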